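Chloro on the Aniline Ring of a Sulfonanilide

A few compounds are considered here, and "the series" means these few. Any claim that something is new, unique, unknown or untested is made for them only; others in the source may bear on it.

Measured so far:
Compound 1, `O=S(=O)(Nc1ccccc1)c1ccccc1`, 9.1
Compound 2, `O=[N+]([O-])c1cccc(NS(=O)(=O)c2ccccc2)c1`, 7.93
Compound 3, `O=[N+]([O-])c1cccc(NS(=O)(=O)c2ccc(Cl)cc2)c1`, 7.51

The three measured compounds share a sulfonanilide framework and were studied in a physicochemical assay for acid dissociation. Compound 1 gives 9.1, the highest of the three. Compound 1 differs from compound 2 by hydrogen in place of nitro on an aromatic carbon, and compound 2 gives 7.93, the step being a number 1.17 log units lower from compound 1 to compound 2 (beyond the scatter). A chloro added to compound 2 gives compound 3, which gives 7.51; this step is a number 0.42 log units lower from compound 2 to compound 3 (beyond the scatter).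

Compound 4, `O=S(=O)(Nc1ccc(Cl)cc1)c1ccccc1`, is not yet measured in this assay. It differs from compound 1 by chloro in place of hydrogen on an aromatic carbon. The same change was made from compound 2 to compound 3, where it gave a number 0.42 log units lower from compound 2 to compound 3 (beyond the scatter); that is the only earlier instance of it among these compounds. The core on which it is now made differs from the core of compound 2 by hydrogen in place of nitro on an aromatic carbon.

Among the measured compounds shown here, on the strength of the one earlier instance, compound 4 is expected to lie below compound 1 by a step of about a number 0.50 log units lower from compound 1 to compound 4 (beyond the scatter), a modest one, resting on the step of a number 0.42 log units lower from compound 2 to compound 3 (beyond the scatter) seen in compound 2 and compound 3. Compound 4 is therefore estimated at 8.6 in this assay, with a likely range from 8.3 to 8.9.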

Compound 4, acid dissociation constant: 8.75
Compound 4: middle estimate off by 0.15 log units, on the low side; measured number inside the range.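

In this assay, chloro in place of hydrogen on an aromatic carbon gives a number 0.35 log units lower from compound 1 to compound 4 (beyond the scatter) on the core without nitro, while the same change on the core bearing nitro gave a number 0.42 log units lower from compound 2 to compound 3 (beyond the scatter); both steps are modest and run in the same direction. This shows that, across these two cores, the change carried over in direction and in broad size, so the presence or absence of the nitro did not reverse it; it does not show that the step would hold on any other core, since two instances are too few to set a general rule for the series. Nothing available bears on the reason for the lower number in either pair, so the result stands here as an observation without an explanation.

The compounds shown leave open whether a methoxy group or an amine in place of the chloro would move the number the same way, and whether fluoro or bromo would give a step of similar size. Also open, from the compounds shown here alone, is whether the chloro step would persist on a core carrying trifluoromethyl or a nitrile in place of the nitro, and what a second chloro would add to compound 4.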